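The source may report more compounds than this note shows. Statements on the series, on what has been measured and on what is new or still open speak of the compounds shown alone.

Compound 1 `CCN(CC)CCn1c(N)c(-c2nc3ccccc3[nH]2)c2nc(C#N)c(C#N)nc21` and compound 2 `CN(C)CCCn1c(N)c(-c2nc3ccccc3[nH]2)c2nc(C#N)c(C#N)nc21` share a core and differ by (dimethylamino)methyl in place of diethylamino on a saturated chain carbon, two bonds along the chain from an aromatic nitrogen. In a functional assay on Raji cells (Homo sapiens) for antiproliferative activity, read by MTT assay, with a stated time of 48 h (on this read-out lower numbers stand for stronger inhibition and higher numbers for weaker inhibition), compound 1 gives 8950 nM, and compound 2 gives 1230 nM; the step is a 7.3-fold lower number from compound 1 to compound 2 (0.86 log units; beyond the scatter). Compound 3 `CCN(CC)CCCn1c(N)c(-c2nc3cc(Cl)ccc3[nH]2)c2nc(C#N)c(C#N)nc21` carries a different core; how its core differs from that of compound 1 is not broken down here. In this assay compound 3 gives 1620 nM. Compound 4 `CN(C)CCCCn1c(N)c(-c2nc3cc(Cl)ccc3[nH]2)c2nc(C#N)c(C#N)nc21` differs from compound 3 by (dimethylamino)methyl in place of diethylamino on a saturated chain carbon, three bonds along the chain from an aromatic nitrogen, the same kind of change as that from compound 1 to compound 2, but made on a saturated chain carbon three bonds rather than two bonds along the chain from an aromatic nitrogen. Because of a 7.3-fold lower number from compound 1 to compound 2 (0.86 log units; beyond the scatter), a step of similar direction is expected, though the longer chain and the other core make its size uncertain, so the expected step is a 3.2-fold lower number from compound 3 to compound 4 (0.51 log units; beyond the scatter). Compound 4 is thus estimated at 500 nM in this assay, within 150 nM to 2000 nM.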

Compound 4, half-maximal inhibitory concentration: 950 nM
The estimate for compound 4 lay 1.9-fold (0.28 log units) below the measured number; low and high end bracket the measured number.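

Replacing 3-(diethylamino)propyl with 4-(dimethylamino)butyl on the core of compound 3 gives a 1.7-fold lower number from compound 3 to compound 4 (0.23 log units; within the scatter) in this assay, a step too small to count as a real change. The change therefore did not carry its earlier size over to this second pair: the same change on two cores in this assay, a 7.3-fold lower number (0.86 log units; beyond the scatter) from compound 1 to compound 2 and a 1.7-fold lower number (0.23 log units; within the scatter) from compound 3 to compound 4, 4.3-fold (0.63 log units) apart, beyond the scatter of two such steps The two pairs differ both in their core and in where along the chain the change sits, so these data cannot separate those two differences or give a cause for the gap.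

Still open, going by these compounds, is what the same chain swap does when the core is held fixed and only the chain differs. Also open, on these data alone, is how a cyclic amine or a longer chain at this position would behave on either core.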